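Swapping the Distal Aryl Group in a Cytotoxicity Series

This account rests on a few compounds, and the source may have more. Where it says the series, first, only, none or still open, it means among the compounds named here.

Compound 1 `CCOC(=O)CCCCCOc1cccc(CN(C(=O)c2ccc(-c3ccc4ccccc4c3)cc2)C(C)C)c1` in an ADME assay on Raji cells (Homo sapiens) for cytotoxicity, read by CellTiter-Glo and resazurin assay, with a stated time of 72 h; on this read-out higher numbers stand for an effect only at larger amounts of compound and lower numbers for an effect already at smaller amounts: > 26000 nM
Compound 2 `CCOC(=O)CCCCCOc1cccc(CN(C(=O)c2ccc(-c3cnc(OC)nc3OC)cc2)C(C)C)c1` in this assay: > 26000 nM
Compound 3 `CCOC(=O)CCCCCOc1cccc(CN(C(=O)c2ccc(-c3cccc(-c4nnc(C)o4)c3)cc2)C(C)C)c1` in this assay: > 26000 nM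

Each of these three values is a limit of the assay and not a measured number. Compound 3 therefore stands at the same limit as its two companions, (the limit of > 26000 nM in this assay, at which 3 of the 3 values shown sit). Because all three sit at that limit, the steps a step that the two limits leave unreadable from compound 1 to compound 2, a step that the two limits leave unreadable from compound 1 to compound 3 and a step that the two limits leave unreadable from compound 2 to compound 3 cannot be read. Compound 4 `CCOC(=O)CCCCCOc1cccc(CN(C(=O)c2ccc(-c3ccc(Cl)c(Cl)c3)cc2)C(C)C)c1` differs from compound 3 by 3,4-dichlorophenyl in place of 3-(5-methyl-1,3,4-oxadiazol-2-yl)phenyl on an aromatic carbon. Within the data shown here, since none of the measured steps has a readable size, no step beyond the scatter is expected in this assay. Compound 4 is expected at 40000 nM, with a range from 20000 nM to 100000 nM. The expected step is a step that the limit leaves unreadable from compound 3 to compound 4, and most likely only a limit will be reported again.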

Compound 4, half-maximal effective concentration: > 26000 nM
Compound 4: only a limit was reported; the forecaster's own chance of this, stated with the estimate: 85%; the middle value is on the limit's open side.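

Compound 4 gives > 26000 nM and this is again only a limit. Its steps from compound 1, compound 2 and compound 3 cannot be read: the limit of > 26000 nM in this assay, at which 4 of the 4 values shown sit.

The compounds shown leave open whether any group at this place would give a measurable value in this assay.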